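From Methyl to Phenylimidazolyl at a Saturated Chain Carbon

The source may report more compounds than this note shows. Statements on the series, on what has been measured and on what is new or still open speak of the compounds shown alone.

Compound 1 `CCC(C)n1ncn(-c2ccc(N3CCN(c4ccc(OC[C@@H]5CO[C@@](CC)(c6ccc(Cl)cc6Cl)O5)cc4)CC3)cc2)c1=O` is the anchor of this small set. In a functional assay on HUVEC cells (Homo sapiens), read by scintillation counting and thymidine incorporation, with a stated time of 24 h (a lower number here means a stronger inhibitor, a higher number a weaker inhibitor), compound 1 gives 353 nM, the lowest of the three numbers, though both neighbours sit within the usual scatter of it. Compound 2 `CCC(C)n1ncn(-c2ccc(N3CCN(c4ccc(OC[C@@H]5CO[C@@](CBr)(c6ccc(Cl)cc6Cl)O5)cc4)CC3)cc2)c1=O` has bromo in place of methyl and gives 569 nM; compound 3 `CCC(C)n1ncn(-c2ccc(N3CCN(c4ccc(OC[C@@H]5CO[C@@](Cc6ccccc6)(c6ccc(Cl)cc6Cl)O5)cc4)CC3)cc2)c1=O` has phenyl in place of methyl and gives 513 nM. The steps of a 1.6-fold higher number from compound 1 to compound 2 (0.21 log units; within the scatter) and a 1.5-fold higher number from compound 1 to compound 3 (0.16 log units; within the scatter) both stay within the scatter, and so does a 1.1-fold lower number from compound 2 to compound 3 (0.04 log units; within the scatter), so nothing tried at this position has moved the number beyond chance.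

Compound 4 `CCC(C)n1ncn(-c2ccc(N3CCN(c4ccc(OC[C@@H]5CO[C@@](Cn6ccnc6-c6ccccc6)(c6ccc(Cl)cc6Cl)O5)cc4)CC3)cc2)c1=O` makes a larger change at the same place: 2-phenyl-1H-imidazol-1-yl in place of methyl on a saturated chain carbon bound to a saturated ring carbon. Both earlier replacements bear on it, and both were small. The entering group is larger than either bromo or phenyl, so a somewhat weaker result is plausible, but the record offers no step beyond the scatter to build on. Compound 4 is therefore expected to give 500 nM, in a range from 200 nM to 1500 nM, which means an expected step of a 1.4-fold higher number from compound 1 to compound 4 (0.15 log units; within the scatter).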

Compound 4, half-maximal inhibitory concentration: 136 nM
Compound 4: the middle estimate sits 3.7-fold (0.57 log units) above what was measured; the measured number lies below the stated range.
By their numbers in this assay, from the lowest: compound 4; then compounds 1, 3 and 2 (each within the scatter of the next).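

Among these compounds, at this saturated chain carbon bound to a saturated ring carbon, the 2-phenyl-1H-imidazol-1-yl group is the first change to move the number in this assay beyond the scatter, with a 2.6-fold lower number from compound 1 to compound 4 (0.41 log units; beyond the scatter) and, against the other two compounds, a 3.8-fold lower number from compound 3 to compound 4 (0.58 log units; beyond the scatter) and a 4.2-fold lower number from compound 2 to compound 4 (0.62 log units; beyond the scatter). A phenyl group at this place is not enough on its own: compound 3 stays within the scatter of compound 1, and only compound 4, whose phenyl sits on a five-membered aromatic ring with two nitrogens, separates from the rest. No measurement offered here explains this gain.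

Going by these compounds, whether the imidazole ring or its phenyl matters more remains open. A plain 1H-imidazol-1-yl group or a simple amine such as dimethylamino at this place would help to separate the two.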